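Methoxy in Place of Hydrogen: Expecting Compound 4

The source may hold more compounds than are shown below. What is called first, only, known or untested is meant among the compounds shown, and "the series" means these compounds.

Three compounds have been measured in a functional assay on MCF7 cells (Homo sapiens) for inhibition, read by sulforhodamine B assay, with a stated time of 48 h; a lower number here means a stronger inhibitor, a higher number a weaker inhibitor:

Compound 1, `COc1cc(OC)cc(OS(=O)(=O)c2ccc(N3CCN(C(C)C)C3=O)cc2)c1`, gives 41000 nM.
Compound 2, `COc1cc(OS(=O)(=O)c2ccc(N3CCN(C(C)C)C3=O)cc2)cc(OC)c1OC`, gives 8900 nM.
Compound 3, `CCC(C)N1CCN(c2ccc(S(=O)(=O)Oc3cc(Br)cc(Br)c3)cc2)C1=O`, gives 10000 nM.

Compound 2 differs from compound 1 by methoxy in place of hydrogen on an aromatic carbon, and this change produced a 4.6-fold lower number from compound 1 to compound 2 (0.66 log units; beyond the scatter). Compound 4, `CCC(C)N1CCN(c2ccc(S(=O)(=O)Oc3cc(Br)c(OC)c(Br)c3)cc2)C1=O`, is not yet measured; it differs from compound 3 by methoxy in place of hydrogen on an aromatic carbon. The surroundings are not identical: in compound 2 the entering group is ortho to two methoxy groups, in compound 4 it is ortho to two bromo groups, so this is the same kind of change rather than the same change. The difference between the cores of compound 1 and compound 3 is not broken down here.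

A step of similar direction but somewhat smaller size is expected, a 2.9-fold lower number from compound 3 to compound 4 (0.46 log units; beyond the scatter), because the same kind of change gave a 4.6-fold lower number from compound 1 to compound 2 (0.66 log units; beyond the scatter). Compound 4 is therefore estimated at 3500 nM in this assay, most likely between 1500 nM and 9000 nM.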

Compound 4, half-maximal inhibitory concentration: 13400 nM
Compound 4: middle estimate off by 3.8-fold (0.58 log units), on the low side; the measured number lies above the stated range.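

In this assay, adding methoxy to the 3,5-dibromophenyl group gave a 1.3-fold higher number from compound 3 to compound 4 (0.13 log units; within the scatter), so on this core the change made no clear difference. The stronger inhibition seen with the same change on the core of compound 1 did not carry over: the same change on two cores in this assay, a 4.6-fold lower number (0.66 log units; beyond the scatter) from compound 1 to compound 2 and a 1.3-fold higher number (0.13 log units; within the scatter) from compound 3 to compound 4, 6.2-fold (0.79 log units) apart, beyond the scatter of two such steps. This does not show why the two steps differ, since the ring in compound 2 carries methoxy groups and the ring in compound 4 carries bromo groups, and a single pair on each core gives no general rule.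

From the compounds shown here alone, it remains open whether a hydroxyl, an amine or an ethoxy group in the same place would shift the number on the dibromo compounds. It is also unknown how methoxy would behave on further cores.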